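This account rests on a few compounds, and the source may have more. Where it says the series, first, only, none or still open, it means among the compounds named here.

In a functional assay on C8166 cells (Homo sapiens) for cytotoxicity, read by MTT assay (a higher number here means that more compound is tolerated, a lower number that less compound is tolerated), three compounds sharing one core have been measured: compound 1 (`Cc1cccc(C(=O)Nc2cc(Cl)ccc2OCC(=O)Nc2ccc(S(N)(=O)=O)cc2C)c1`) gives 52900 nM, compound 2 (`Cc1cc(C)cc(C(=O)Nc2cc(Cl)ccc2OCC(=O)Nc2ccc(S(N)(=O)=O)cc2C)c1`) gives 36500 nM, and compound 3 (`Cc1cc(S(N)(=O)=O)ccc1NC(=O)COc1ccc(Cl)cc1NC(=O)c1cc(Cl)ccc1Cl`) gives 42100 nM. Compound 3 therefore stands within the scatter of both others. Compound 4 (`Cc1cc(S(N)(=O)=O)ccc1NC(=O)COc1ccc(Cl)cc1NC(=O)c1cc(Br)cc(Br)c1`) carries 3,5-dibromophenyl in place of 2,5-dichlorophenyl on a carbonyl carbon. Three measured steps, all changes in the group on that carbonyl carbon, bear on this: a 1.3-fold lower number from compound 1 to compound 3 (0.10 log units; within the scatter), a 1.2-fold higher number from compound 2 to compound 3 (0.06 log units; within the scatter) and a 1.4-fold lower number from compound 1 to compound 2 (0.16 log units; within the scatter). Among the compounds with values here, each lies within the scatter, although none of the measured compounds carries bromine. No step beyond the scatter is therefore expected in this assay. The estimated step is a 1.2-fold lower number from compound 3 to compound 4 (0.08 log units; within the scatter). Compound 4 is estimated at 35000 nM, with an expected range of 17000 nM to 70000 nM.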

Compound 4, half-maximal cytotoxic concentration: 89700 nM
For compound 4 the middle estimate is 2.6-fold (0.41 log units) below the measured one; measured number above the stated range.
By their numbers in this assay, from the lowest: compounds 2, 3, 1 and 4 (each within the scatter of the next, the first and the last beyond it).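

In this assay, within the data shown here, the group on this carbonyl carbon moves the number beyond the scatter for the first time: 3,5-dibromophenyl gives a 2.1-fold higher number from compound 3 to compound 4 (0.33 log units; beyond the scatter) and a 2.5-fold higher number from compound 2 to compound 4 (0.39 log units; beyond the scatter) and both steps are modest. Compound 1 goes against a clean separation, since a 1.7-fold higher number from compound 1 to compound 4 (0.23 log units; within the scatter) stays within the scatter. Nothing available explains the step.

Open, as far as these compounds go, is whether the two bromines are both needed for this step, and how the number responds to an amine or a carboxylic acid on that phenyl ring.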